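From Chlorophenyl to Dimethoxyphenyl in Growth Inhibition

The source may report more compounds than this note shows. Statements on the series, on what has been measured and on what is new or still open speak of the compounds shown alone.

Measured in a functional assay on A2780 cells (Homo sapiens) for inhibition, read by sulforhodamine B assay; on this read-out lower numbers stand for stronger inhibition of growth and higher numbers for weaker inhibition of growth:
Compound 1 `CN(C)c1ccc(-c2ccc(-c3ccc(-c4nc5ccccc5[nH]4)cc3)cc2)cc1`: 100000 nM
Compound 2 `Clc1cccc(-c2ccc(-c3ccc(-c4nc5ccccc5[nH]4)cc3)cc2)c1`: 31100 nM

Of these two numbers, the lower belongs to compound 2. Next comes compound 3 `COc1ccc(-c2ccc(-c3ccc(-c4nc5ccccc5[nH]4)cc3)cc2)cc1OC`, with 3,4-dimethoxyphenyl in place of 3-chlorophenyl on an aromatic carbon. Among the compounds with values here, the one measured step, a 3.2-fold lower number from compound 1 to compound 2 (0.51 log units; beyond the scatter), alters the same place and is modest. A step of similar size, toward a higher number, is therefore expected in this assay. The expected change is a 1.4-fold higher number from compound 2 to compound 3 (0.16 log units; within the scatter). For compound 3 the estimated value is 45000 nM, with an expected range of 15000 nM to 120000 nM.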

Compound 3, concentration for 50% growth inhibition: 21600 nM
Beside the measured number, compound 3's estimate is 2.1-fold (0.32 log units) above it; low and high end bracket the measured number.
By their numbers in this assay, from the lowest: compounds 3 and 2 (each within the scatter of the next); then compound 1.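

In this assay, 3,4-dimethoxyphenyl in place of 3-chlorophenyl gives a 1.4-fold lower number from compound 2 to compound 3 (0.16 log units; within the scatter), so at this position a group carrying hydrogen-bond acceptors cannot be told apart from a chlorinated one. Against 4-(dimethylamino)phenyl, the same group gives a 4.6-fold lower number from compound 1 to compound 3 (0.67 log units; beyond the scatter), so two different groups now lie beyond the scatter from compound 1. Nothing available explains these differences. Still open, as far as these compounds go, is how an unsubstituted phenyl or a ring bearing a carboxylic acid would compare at this position.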